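This account rests on a few compounds, and the source may have more. Where it says the series, first, only, none or still open, it means among the compounds named here.

Compound 1 `CCCc1cccc(C[C@H](O)/C=C/[C@H]2CSC(=O)N2CCSCCCC(=O)O)c1`: 1200 nM
Compound 2 `O=C(O)CCCSCCN1C(=O)OC[C@@H]1/C=C/[C@@H](O)Cc1ccccc1`: 6400 nM
Compound 3 `O=C(O)CCCSCCN1C(=O)SC[C@@H]1/C=C/[C@@H](O)Cc1cccc(C(F)(F)F)c1`: 280 nM

In an assay on CHO cells for displacement of a labelled ligand from prostaglandin E2 receptor EP3 subtype (Mus musculus), read by scintillation counting, with a stated time of 60 min (on this read-out lower numbers stand for stronger inhibition and higher numbers for weaker inhibition), compound 2 gives the highest of the three numbers; compound 1 stands nearest with a lower number, and compound 3 stands furthest with the lowest. Compound 4 `COCc1cccc(C[C@H](O)/C=C/[C@H]2COC(=O)N2CCSCCCC(=O)O)c1` differs from compound 2 by methoxymethyl in place of hydrogen on an aromatic carbon. Among the compounds with values here, the one measured step in this assay, a 4.3-fold lower number from compound 1 to compound 3 (0.63 log units; beyond the scatter), exchanges one group for another on the same kind of aromatic carbon rather than adding a group where hydrogen stood, so it bears only loosely on this change. Compound 2, whose ring carries no group at that position, has the highest number, while compounds 1 and 3, each carrying a group there, have lower numbers, though both differ from compound 2 in more than one place. A modest lowering of the number is therefore expected for compound 4, with wide uncertainty. Compound 4 is expected to give 2500 nM in this assay, within a range of 900 nM to 7000 nM, which corresponds to an estimated step of a 2.6-fold lower number from compound 2 to compound 4 (0.41 log units; beyond the scatter).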

Compound 4, inhibition constant: > 10000 nM
Compound 4 was reported as a limit (the forecaster's own chance of this, stated with the estimate: 5%); at least 4.0-fold (0.60 log units) between middle value and limit.
By their numbers in this assay, from the lowest: compound 3; then compound 1; then compound 2. At a limit, above all of these: compound 4.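

Putting methoxymethyl in place of hydrogen on this aromatic carbon, meta to a large group, gives an at least 1.5-fold higher number from compound 2 to compound 4 (0.19 log units; that floor lies within the scatter), the only step shown that adds a group where hydrogen stood rather than exchanging one group for another. It therefore shows that a group at this position does not by itself lower the number, although this floor alone does not establish a change beyond the scatter. In this assay compound 4 is reported only as a limit, not as a number: the limit of > 10000 nM in this assay, at which 1 of the 4 values shown sits.

On these data alone, how far the number rises from compound 2 to compound 4 remains open, and so does whether propyl or trifluoromethyl in place of hydrogen on the core of compound 2 would lower it. As far as these compounds go, the effect of an amine, a carboxylic acid or a longer chain at this carbon also remains open.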